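Swapping 5-nitrothiophen-3-yl for 2,3-dichlorophenyl

The compounds below may be only part of what the source reports. "The series", "measured", "known", "first", "only" and "open" are said of these compounds alone.

Compound 1 `Cc1oc2c([C@H]3CCN(C)C[C@H]3O)c(O)cc(O)c2c(=O)c1C(O)c1ccccc1Br` gives 21% here
Compound 2 `Cc1oc2c([C@H]3CCN(C)C[C@H]3O)c(O)cc(O)c2c(=O)c1C(O)c1csc([N+](=O)[O-])c1` gives 20% here

In a functional assay on MCF7 cells (Homo sapiens) for inhibition, read by MTT assay, with a stated time of 48 h, tested at 10 uM (a higher number here means more inhibition of growth at the concentration tested, a lower number less inhibition of growth), compound 2 gives 20% and lies within the scatter of compound 1 at 21% in this small set. Compound 3 `Cc1oc2c([C@H]3CCN(C)C[C@H]3O)c(O)cc(O)c2c(=O)c1C(O)c1cccc(Cl)c1Cl` has not yet been measured. It carries 2,3-dichlorophenyl in place of 5-nitrothiophen-3-yl on a saturated chain carbon bound to an aromatic carbon and an oxygen on a saturated carbon, a change counted as 2,3-dichlorophenyl in place of 5-nitrothiophen-3-yl on a saturated chain carbon bound to an aromatic carbon and an oxygen on a saturated carbon on the shared core. Among the compounds with values here, one measured step bears on it at that same carbon, a number 1 percentage points lower from compound 1 to compound 2 (within the scatter) and it stays within the scatter. No shift beyond the scatter is therefore expected in this assay for this exchange. The expected step is a number 2 percentage points higher from compound 2 to compound 3 (within the scatter) and so remains small. Compound 3 is estimated at 22% with an expected range of 10% to 38% when tested.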

Compound 3, percent growth inhibition at one concentration: 7%
Compound 3: the middle estimate sits 15 percentage points above what was measured, and the stated range ends above it.
By their numbers in this assay, from the lowest: compound 3; then compounds 2 and 1 (each within the scatter of the next).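

In this assay, the group on the saturated chain carbon bound to an aromatic carbon and an oxygen on a saturated carbon can shift the read-out beyond the scatter: 2,3-dichlorophenyl gives a number 13 percentage points lower from compound 2 to compound 3 (beyond the scatter) and a number 14 percentage points lower from compound 1 to compound 3 (beyond the scatter), while the earlier exchange at this carbon stayed within it. The 5-nitrothiophen-3-yl and 2,3-dichlorophenyl groups have the same heavy-atom count, so that count does not follow this step. No measurement shown here explains why the number falls.

As far as these compounds go, it remains open whether both chlorines are needed for the lower number, or whether a phenyl ring carrying a single chlorine would read the same. Also open, from the compounds shown here alone, is how an amine or a carboxylic acid would read in place of the aromatic ring at this carbon.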